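Anilide series at the dopamine receptor: chloro to methyl

The compounds below may be only part of what the source reports. "The series", "measured", "known", "first", "only" and "open" are said of these compounds alone.

Working notes on a set of anilides sharing one amide-linked core. Compound 1 `Cc1cccc(NC(=O)CN2CCC(c3ccc(Cl)cc3)CC2)c1`, in a functional assay on cells for agonist activity at D(4) dopamine receptor (Homo sapiens), read by TR-FRET and cAMP accumulation, with a stated time of 30 min (on this read-out higher numbers stand for an effect only at larger amounts of compound and lower numbers for an effect already at smaller amounts), is recorded as "not active" (no number reported), and no number stands for it, so its place on the scale cannot be fixed. Two related compounds do carry numbers: compound 2 `Cc1cccc(NC(=O)CCN2CCN(c3ncccn3)CC2)c1` gives 568 nM in this assay, and compound 3 `Cc1cccc(NC(=O)CCN2CCC(c3ccccn3)CC2)c1` gives 349 nM in this assay. The two values of compound 2 and compound 3 lie within the usual scatter of each other, so nothing is said here about their order.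

The next compound, compound 4 `Cc1ccc(C2CCN(CC(=O)Nc3cccc(C)c3)CC2)cc1`, differs from compound 1 in one place only: methyl in place of chloro on an aromatic carbon. Both groups count one heavy atom, carry no ring, add no hydrogen-bond donor or acceptor and bring no charge. Among the measured compounds shown here, no measured step reports what this change does on its own.

Given that compound 1 shows no activity here, the expectation for compound 4 is that it too remains without a clear effect, with the chance of a reported number rather than an inactive call judged small. The estimate for compound 4 in this assay is 10000 nM, within 1500 nM to 40000 nM.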

Compound 4, half-maximal effective concentration: "not active" (no number reported)
For compound 4 the study gives words and no number; there is nothing to compare the estimate with.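

In this assay compound 1 and compound 4 are both recorded in words without a number, so no step can be read for the change from 4-chlorophenyl to 4-methylphenyl. No measurement shown bears on this result. The compounds shown leave open what this change does in a compound with a numbered response.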